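A few compounds are considered here, and "the series" means these few. Any claim that something is new, unique, unknown or untested is made for them only; others in the source may bear on it.

Values in a functional assay on LNCaP cells (Homo sapiens) for cytotoxicity, read by MTT assay, with a stated time of 5 days; on this read-out higher numbers stand for weaker inhibition of growth and lower numbers for stronger inhibition of growth:
- compound 1 `Cc1ccc(NS(=O)(=O)c2ccccc2)c([N+](=O)[O-])c1`: 2.95 nM
- compound 2 `O=S(=O)(Nc1ccccc1)c1ccccc1`: 53500 nM
- compound 3 `Cc1ccc(/N=C/c2ccccc2)cc1`: "not determined" (no result reported)

Compound 2 stands highest of the two numbers in this assay, and its gap to compound 1 lies well beyond the scatter. Compound 3 offers no number for comparison. The next compound to be read is compound 4 `Cc1ccc(NS(=O)(=O)c2ccccc2)cc1`, which differs from compound 2 by methyl in place of hydrogen on an aromatic carbon. Within the data shown here, no measured pair isolates this change. A small shift towards stronger inhibition of growth is expected, close to the scatter. The estimated change is a 1.8-fold lower number from compound 2 to compound 4 (0.25 log units; within the scatter). For compound 4 the expected value is 30000 nM, with an estimated range of 6000 nM to 90000 nM.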

Compound 4, concentration for 50% growth inhibition: 21300 nM
Beside the measured number, compound 4's estimate is 1.4-fold (0.15 log units) above it; the measured number falls inside the stated range.
By their numbers in this assay, from the lowest: compound 1; then compound 4; then compound 2.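

In this assay, methyl on an aromatic carbon para to a large group gives a 2.5-fold lower number from compound 2 to compound 4 (0.40 log units; beyond the scatter), so this position responds modestly to the addition of one carbon. Hydrogen in place of nitro on an aromatic carbon is a far larger step, a 7200-fold higher number from compound 1 to compound 4 (3.86 log units; beyond the scatter), and the methyl alone leaves compound 4 far from compound 1. No measurement bearing on the origin of either step is available.

Still open, going by these compounds, is how nitro behaves on the core of compound 2 without the methyl. Also open, on these data alone, is whether an amine, a carboxylic acid or a longer chain at the methyl position would move the number further.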